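Swapping a Methyl for Hydrogen on the Hydroxyalkyl Chain

This account rests on a few compounds, and the source may have more. Where it says the series, first, only, none or still open, it means among the compounds named here.

Three ureas built on a pyrazole ester were tested in a functional assay on cells (Neutrophil, Homo sapiens) for inhibition, with a stated time of 10 min; on this read-out lower numbers stand for stronger inhibition and higher numbers for weaker inhibition. Compound 1 `CCOC(=O)c1cnn(CC(O)CC)c1NC(=O)Nc1cccc2ccccc12` gives 9.6 nM. Compound 3 `CCOC(=O)c1cnn(CC(O)CC)c1NC(=O)Nc1cccc(F)c1` gives 0.36 nM; the difference between its core and that of compound 1 is not broken down here. Compound 2 `CCOC(=O)c1cnn(CC(C)O)c1NC(=O)Nc1cccc(F)c1` gives 0.0007 nM. The change from compound 3 to compound 2 is hydrogen in place of methyl on a saturated chain carbon, two bonds along the chain from an oxygen on a saturated carbon, and it brought a 510-fold lower number from compound 3 to compound 2 (2.71 log units; beyond the scatter).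

Compound 4 `CCOC(=O)c1cnn(CC(C)O)c1NC(=O)Nc1cccc2ccccc12` is not yet measured. It arises from compound 1 by the same change, (hydrogen in place of methyl on a saturated chain carbon, two bonds along the chain from an oxygen on a saturated carbon). Because compound 3 to compound 2 gave a 510-fold lower number from compound 3 to compound 2 (2.71 log units; beyond the scatter), a step of about the same size is expected from compound 1 to compound 4 in this assay, namely a 320-fold lower number from compound 1 to compound 4 (2.51 log units; beyond the scatter), though a single earlier example makes this uncertain. Compound 4 is therefore estimated at 0.03 nM, likely between 0.002 nM and 1 nM.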

Compound 4, half-maximal inhibitory concentration: 0.00097 nM
The estimate for compound 4 lay 31-fold (1.49 log units) above the measured number, and the stated range ends above it.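

In this assay going from 2-hydroxybutyl to 2-hydroxypropyl gives a 9900-fold lower number from compound 1 to compound 4 (4.00 log units; beyond the scatter) and so the direction of the step is the same on both cores shown. The size did not carry over, so the earlier step pointed the right way but did not fix how large the later one would be: the same change on two cores in this assay, a 510-fold lower number (2.71 log units; beyond the scatter) from compound 3 to compound 2 and a 9900-fold lower number (4.00 log units; beyond the scatter) from compound 1 to compound 4, 19-fold (1.28 log units) apart, beyond the scatter of two such steps. Within the data shown here, two cores are only two examples, and they show neither why the steps differ in size nor what the change would do on any other core.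

The compounds shown leave open how a shorter chain such as 2-hydroxyethyl or a longer one such as 2-hydroxypentyl would compare. They also leave open what an amine in place of the hydroxyl on the chain would do.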